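The source may report more compounds than this note shows. Statements on the series, on what has been measured and on what is new or still open speak of the compounds shown alone.

Working notes on the series

Compound 1 `C[Se]/C(=N\C(=O)c1ccco1)NC(=O)c1ccco1` and compound 2 `CS/C(=N\C(=O)c1ccco1)NC(=O)c1ccco1` share one core and differ only at the carbon with a double bond to nitrogen. In an ADME assay on MCF-10A cells (Homo sapiens) for cytotoxicity, read by MTT assay, with a stated time of 72 h (a lower number here means a stronger inhibitor of growth, a higher number a weaker inhibitor of growth), compound 1 gives 40200 nM, and in this assay compound 2 gives 46500 nM. The step of a 1.2-fold higher number from compound 1 to compound 2 (0.06 log units; within the scatter) shows that exchanging the selenium-bearing group for the sulfur-bearing one left the read-out unchanged. Among the compounds with values here, compound 2 therefore stands alongside compound 1, the two numbers lying within the scatter of each other, with no further measured compound to place it against.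

Compound 3 `O=C(/N=C(/NC(=O)c1ccco1)[Se]Cc1ccccc1)c1ccco1` carries the change (a group of 8 heavy atoms (7 carbon, 1 selenium; one six-membered aromatic ring of carbon only) in place of a group of 2 heavy atoms (1 carbon, 1 sulfur; no ring), on a carbon with a double bond to nitrogen). Within the data shown here, only the step from compound 1 to compound 2 bears on it, and that step was within the scatter; it covers the return to selenium, but nothing measured covers the benzyl part. The expectation for compound 3 in this assay is a number close to that of compound 2, with the step of a 1.6-fold lower number from compound 2 to compound 3 (0.19 log units; within the scatter) expected to stay within or near the scatter. The estimate for compound 3 is 30000 nM, with a range from 10000 nM to 90000 nM.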

Compound 3, concentration for total growth inhibition: 58000 nM
Compound 3: the middle estimate sits 1.9-fold (0.29 log units) below what was measured, within the range that was stated.
By their numbers in this assay, from the lowest: compounds 1, 2 and 3 (each within the scatter of the next).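

In this assay, within the data shown here, the step of a 1.4-fold higher number from compound 1 to compound 3 (0.16 log units; within the scatter) covers the benzyl part for the first time: phenyl in place of hydrogen on a saturated chain carbon bound to a selenium atom stays within the scatter. The step of a 1.2-fold higher number from compound 2 to compound 3 (0.10 log units; within the scatter) adds that on a carbon with a double bond to nitrogen, the group of 8 heavy atoms with its six-membered aromatic ring of carbon only cannot be told apart from methylsulfanyl, so among these three compounds a ring in this group shows no effect on the read-out. No available finding bears on the reason for this.

On these data alone, whether an amine or a carboxylic acid on that saturated chain carbon would give a step beyond the scatter remains open. Also open, as far as these compounds go, is whether a longer chain in place of the benzyl part would do so.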